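The source may report more compounds than this note shows. Statements on the series, on what has been measured and on what is new or still open speak of the compounds shown alone.

Compound 1 `CN(C[C@@H]1CCCc2cc(S(=O)(=O)c3cccc(F)c3)ccc21)S(N)(=O)=O` gives 3.98 nM in an assay on isolated protein for displacement of a labelled ligand from 5-hydroxytryptamine receptor 6 (Homo sapiens); on this read-out higher numbers stand for weaker inhibition and lower numbers for stronger inhibition.
Compound 2 `CNC(=O)NC[C@@H]1CCCc2cc(S(=O)(=O)c3cccc(F)c3)ccc21` gives 0.398 nM in this assay.
Compound 3 `COC(=O)NC[C@@H]1CCCc2cc(S(=O)(=O)c3cccc(F)c3)ccc21` gives 1.59 nM in this assay.

Compound 3 stands second highest of the three: a 2.5-fold lower number from compound 1 to compound 3 (0.40 log units; beyond the scatter) and a 4.0-fold higher number from compound 2 to compound 3 (0.60 log units; beyond the scatter). Compound 4 `CC(=O)N(C)C[C@@H]1CCCc2cc(S(=O)(=O)c3cccc(F)c3)ccc21` has acetyl(methyl)amino in place of (methoxycarbonyl)amino on a saturated chain carbon bound to a saturated ring carbon. For the measured compounds named here, no measured step covers this group; the nearest guides are a 2.5-fold lower number from compound 1 to compound 3 (0.40 log units; beyond the scatter) and a 4.0-fold higher number from compound 2 to compound 3 (0.60 log units; beyond the scatter), which show that exchanging the terminal group here moves this assay only modestly. Compound 1, which also carries a methyl on the nitrogen and no amide hydrogen, gave the highest number, so a modest rise is expected. Compound 4 is expected to give about 3.2 nM, within 1 nM to 10 nM. The estimate means a 2.0-fold higher number from compound 3 to compound 4 (0.30 log units; within the scatter).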

Compound 4, inhibition constant: 1.59 nM
Beside the measured number, compound 4's estimate is 2.0-fold (0.30 log units) above it; low and high end bracket the measured number.
By their numbers in this assay, from the lowest: compound 2; then compounds 3 and 4 (each within the scatter of the next); then compound 1.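

Acetyl(methyl)amino in place of (methoxycarbonyl)amino gives no change at the digits printed from compound 3 to compound 4 (within the scatter) in this assay, so a group with 0 hydrogen-bond donors can stand at this place with no readable loss against compound 3. The same group still leaves a 4.0-fold higher number from compound 2 to compound 4 (0.60 log units; beyond the scatter), while exchanging sulfamoyl for acetyl on the amine nitrogen gives a 2.5-fold lower number from compound 1 to compound 4 (0.40 log units; beyond the scatter), so compound 2 keeps the lowest number of the four. Nothing measured here explains these steps. Going by these compounds, how acetylamino without the methyl would read remains open, as does the effect of a free amine or a carboxylic acid at this place.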